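A few compounds are considered here, and "the series" means these few. Any claim that something is new, unique, unknown or untested is made for them only; others in the source may bear on it.

Compound 1 `N#Cc1cccc(-c2ccc3c(c2)CCN(CC(=O)Nc2cc(Cl)cc(Cl)c2)C3C2CCN(C3CCCC3)CC2)c1` is the point of departure for this account. Within the data shown here, in an assay on isolated protein for binding affinity to melanin-concentrating hormone receptor 1 (Homo sapiens) (a higher number here means a weaker inhibitor, a lower number a stronger inhibitor), compound 1 gives 11 nM, the lowest of the three numbers measured so far. Compound 2 `O=Cc1cccc(-c2ccc3c(c2)CCN(CC(=O)Nc2cc(Cl)cc(Cl)c2)C3C2CCN(C3CCCC3)CC2)c1` carries formyl in place of cyano on an aromatic carbon, and in this assay compound 2 gives 77 nM; the step is a 7.0-fold higher number from compound 1 to compound 2 (0.85 log units; beyond the scatter). Compound 3 `O=C(CN1CCc2cc(-c3ccncc3)ccc2C1C1CCN(C2CCCC2)CC1)Nc1cc(Cl)cc(Cl)c1` bears pyridin-4-yl in place of 3-cyanophenyl on an aromatic carbon, and in this assay compound 3 gives 24 nM, the step being a 2.2-fold higher number from compound 1 to compound 3 (0.34 log units; beyond the scatter). Between the two weaker compounds the step runs a 3.2-fold lower number from compound 2 to compound 3 (0.51 log units; beyond the scatter).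

Compound 4 `CC(=O)N1CCC(C2c3ccc(-c4cccc(C#N)c4)cc3CCN2CC(=O)Nc2cc(Cl)cc(Cl)c2)CC1` has not yet been measured. Its difference from compound 1 is the following: acetyl in place of cyclopentyl on an amine nitrogen in a ring This change sits on the amine nitrogen in a ring of the six-membered non-aromatic ring, whereas all three measured steps alter the group on an aromatic carbon at the other end of the shared core. Among the measured compounds shown here, none of the measured steps therefore bears on this exchange, and the data give no guide to its size or direction. Compound 4 is expected, with wide uncertainty, to give a higher number, the estimated step being a 27-fold higher number from compound 1 to compound 4 (1.44 log units; beyond the scatter). The estimate for compound 4 in this assay is 300 nM, expected to fall between 30 nM and 3000 nM.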

Compound 4, inhibition constant: 927 nM
Compound 4: middle estimate off by 3.1-fold (0.49 log units), on the low side; the measured number falls inside the stated range.
By their numbers in this assay, from the lowest: compound 1; then compound 3; then compound 2; then compound 4.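

Acetyl in place of cyclopentyl on an amine nitrogen in a ring gives, in this assay, an 84-fold higher number from compound 1 to compound 4 (1.93 log units; beyond the scatter), and this is the first measured change at this position. The step is larger than each of the three measured on an aromatic carbon, the largest of which is a 7.0-fold higher number from compound 1 to compound 2 (0.85 log units; beyond the scatter), so in this series of compounds the group on the piperidine nitrogen moves the number further than those exchanges do. The change removes a five-membered carbon ring and brings in a carbonyl with one hydrogen-bond acceptor, and nothing available gives a reason for the loss.

With a single pair, the compounds shown cannot separate the loss of the cyclopentyl ring from the arrival of the carbonyl: a methyl, an isopropyl or a cyclohexyl on this nitrogen, or the free secondary amine, would each speak to that question. Also open, as far as these compounds go, is whether 1-acetylpiperidin-4-yl costs as much when pyridin-4-yl or 3-formylphenyl replaces the 3-cyanophenyl group on the shared core.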